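The compounds below may be only part of what the source reports. "The series", "measured", "known", "first", "only" and "open" are said of these compounds alone.

Two compounds share a core and differ only in the group hanging from the ring nitrogen. Compound 1 `CCc1cnc(N2CCC(CCCNc3ccc4c(c3)OCC4=O)CC2)nc1` and compound 2 `COc1cnc(N2CCC(CCCNc3ccc4c(c3)OCC4=O)CC2)nc1` were both tested in a functional assay on CHO-K1 cells for agonist activity at Glucose-dependent insulinotropic receptor (Mus musculus), read by HTRF and cAMP accumulation, with a stated time of 30 min; a lower number here means a smaller maximal response, a higher number a larger maximal response; compound 1 gives 98% and compound 2 gives 106%. For the measured compounds named here, the only measured step, a number 8 percentage points higher from compound 1 to compound 2 (within the scatter), shows that swapping one small group for another on that aromatic ring left the maximal response essentially unchanged.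

Compound 3 `CC(C)c1nc(N2CCC(CCCNc3ccc4c(c3)OCC4=O)CC2)no1` carries a different ring on the same nitrogen, but in this assay compound 3 gives "not determined" (no result reported), that is, no number was reported for it, so its standing rests on the neighbours alone.

Compound 4 `CC(C)c1nnc(N2CCC(CCCNc3ccc4c(c3)OCC4=O)CC2)o1` is built from the same atoms as compound 3, joined differently: 5-isopropyl-1,3,4-oxadiazol-2-yl in place of 5-isopropyl-1,2,4-oxadiazol-3-yl on an amine nitrogen in a ring. Going by the values given here, no measured step mirrors this kind of rearrangement, and the one step that exists is within the scatter, so there is no basis to expect a step beyond the scatter in this assay in either direction. Compound 4 is therefore expected to give about 100%, within a range from 70% to 120%.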

Compound 4, largest response reached (Emax), in percent of the reference or control that the assay uses: 88%
For compound 4 the middle estimate is 12 percentage points above the measured one; low and high end bracket the measured number.
By their numbers in this assay, from the lowest: compounds 4, 1 and 2 (each within the scatter of the next, the first and the last beyond it).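

Compound 4 gives this position its first measured ring that is not a pyrimidine, and the maximal response in this assay stays large with 5-isopropyl-1,3,4-oxadiazol-2-yl on the amine nitrogen. Against the methoxy neighbour, this exchange gives a number 18 percentage points lower from compound 2 to compound 4 (beyond the scatter) and is the only step so far that clears the scatter. Against the ethyl neighbour, it gives a number 10 percentage points lower from compound 1 to compound 4 (within the scatter) and so cannot be told apart from no change, which means the effect of the new ring depends on which pyrimidine it is compared with.

The compounds shown leave open how the isomeric 5-isopropyl-1,2,4-oxadiazol-3-yl ring compares, and whether a group without a ring, such as a carbamate, would keep the response on this nitrogen. The data shown offer no measurement that would explain the step.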